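Moving two methyl groups along the amine chain

The compounds below may be only part of what the source reports. "The series", "measured", "known", "first", "only" and "open" are said of these compounds alone.

Compound 2 `CC(C)(N)CC(=O)N[C@@H]1CCc2ccccc2N(Cc2ccc(-c3ccccc3-c3nn[nH]n3)cc2)C1=O` gives the lowest of the two numbers in a functional assay on cells (Pituitary gland cell) with growth hormone secretagogue receptor type 1 (Rattus norvegicus) as the target (on this read-out lower numbers stand for an effect already at smaller amounts and higher numbers for an effect only at larger amounts of compound), at 0.06 uM, while compound 1 `NCCC(=O)N[C@@H]1CCc2ccccc2N(Cc2ccc(-c3ccccc3-c3nn[nH]n3)cc2)C1=O` sits at 2 uM. Compound 3 `CC(C)(CN)C(=O)N[C@@H]1CCc2ccccc2N(Cc2ccc(-c3ccccc3-c3nn[nH]n3)cc2)C1=O` keeps the same atoms but joins them differently: 1-(aminomethyl)-1-methylethyl in place of 2-amino-2-methylpropyl on a carbonyl carbon. For the measured compounds named here, the one measured step that bears on this, a 33-fold lower number from compound 1 to compound 2 (1.52 log units; beyond the scatter), shows how much 1-amino-1-methylethyl gained over aminomethyl. Compound 3 carries an aminomethyl again, so part of that gain is expected to be lost. The expected step is an 8.3-fold higher number from compound 2 to compound 3 (0.92 log units; beyond the scatter). Compound 3 is therefore estimated at 0.5 uM, within 0.1 uM to 3 uM.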

Compound 3, concentration for half-maximal effect: 3 uM
Estimate against measurement, compound 3: 6.0-fold (0.78 log units) below; low and high end bracket the measured number.
By their numbers in this assay, from the lowest: compound 2; then compounds 1 and 3 (each within the scatter of the next).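

Joining the same atoms differently gives a 50-fold higher number from compound 2 to compound 3 (1.70 log units; beyond the scatter) in this assay and so the arrangement of the chain, not its atoms, decides the result here. With a 1.5-fold higher number from compound 1 to compound 3 (0.18 log units; within the scatter) the 1-(aminomethyl)-1-methylethyl group cannot be told apart from 2-aminoethyl, so this isomer does not share the gain seen with 2-amino-2-methylpropyl. Nothing measured here offers a reason for this difference.

Still open, going by these compounds, is whether a single methyl group on the chain would keep the gain. Also open, on these data alone, is how a longer chain, such as 3-amino-3-methylbutyl, would behave on the same carbonyl carbon.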